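Swapping the Side Chain on an Amine Nitrogen

This account rests on a few compounds, and the source may have more. Where it says the series, first, only, none or still open, it means among the compounds named here.

- compound 1 `COc1ccc(CCCNCc2c(OC)cc(Oc3ccc(Nc4ccccc4)cc3)cc2OC)cc1`: 14600 nM
- compound 2 `COc1cc(Oc2cccc(Nc3ccccc3)c2)cc(OC)c1CNCCNC(C)=O`: 11900 nM
- compound 3 `COc1ccc([C@@H](C)NCc2c(OC)cc(Oc3cccc(Nc4ccccc4)c3)c(OC)c2OC)cc1`: 8250 nM

In a functional assay on SW-620 cells (Homo sapiens) for inhibition, read by MTT assay, with a stated time of 72 h (a higher number here means a weaker inhibitor, a lower number a stronger inhibitor), compound 2 gives 11900 nM, a value within the usual scatter of both compound 1 and compound 3. None of the three compounds can therefore be separated from the others on these numbers.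

The next compound to be tested is compound 4 `COc1cc(Oc2cccc(Nc3ccccc3)c2)cc(OC)c1CNC(C)C`. It has isopropyl in place of 2-acetamidoethyl on an amine nitrogen, and the rest of compound 2 stays as it is.

Among the measured compounds shown here, no measured pair isolates this change, so any expectation rests on indirect evidence. Compound 1 at 14600 nM and compound 3 at 8250 nM carry other groups on the amine nitrogen and also differ elsewhere, yet they stay close to compound 2. In this assay the expected result is therefore no shift beyond the scatter, with an estimated 1.5-fold lower number from compound 2 to compound 4 (0.17 log units; within the scatter). For compound 4 the estimated value is 8000 nM, with an expected range from 3000 nM to 20000 nM.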

Compound 4, half-maximal inhibitory concentration: > 20000 nM
Compound 4: a limit, no number; the forecaster's own chance of this, stated with the estimate: 10%; middle value at least 2.5-fold (0.39 log units) away from the limit.
By their numbers in this assay, from the lowest: compounds 3, 2 and 1 (each within the scatter of the next). At a limit, above all of these: compound 4.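

In this assay compound 4 gives > 20000 nM, which is a limit of the assay and not a number. Among the compounds shown here, this gives the first single-change reading on this amine nitrogen: an at least 1.6-fold higher number from compound 2 to compound 4 (0.22 log units; that floor lies within the scatter). Isopropyl in place of 2-acetamidoethyl therefore brings no sign of a lower number, but how far compound 4 really lies from compound 2 cannot be told: the limit of > 20000 nM in this assay, at which 1 of the 4 values shown sits.

The compounds shown leave open whether the acetamido part of the side chain matters or only the chain itself. A 2-aminoethyl group, a 2-hydroxyethyl group or a longer plain chain such as n-butyl on the same amine nitrogen, with the rest of compound 2 unchanged, would separate these two readings.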